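The source may report more compounds than this note shows. Statements on the series, on what has been measured and on what is new or still open speak of the compounds shown alone.

In a functional assay on Ehrlich cells (Mus musculus) for cytotoxicity, read by trypan blue exclusion, with a stated time of 2 h, tested at 100 ug/mL (on this read-out higher numbers stand for a stronger effect at the one concentration tested and lower numbers for a weaker effect), compound 1, `CC(Cl)CC(=O)NC1=C(C#N)C(c2ccc(Cl)cc2Cl)C2=C(CCCC2=O)N1c1ccc(S(N)(=O)=O)cc1`, gives 60%. Compound 2, `CN(C)c1ccc(/C=N/C2=C(C#N)C(c3ccc(Cl)cc3Cl)C3=C(CCCC3=O)N2c2ccc(S(N)(=O)=O)cc2)cc1`, gives 40% in this assay, and the step of a number 20 percentage points lower from compound 1 to compound 2 (beyond the scatter). Compound 3, `CN(C)c1ccc(/C=C/C=N/C2=C(C#N)C(c3ccc(Cl)cc3Cl)C3=C(CCCC3=O)N2c2ccc(S(N)(=O)=O)cc2)cc1`, gives 20% in this assay, a further step of a number 20 percentage points lower from compound 2 to compound 3 (beyond the scatter). Compound 3 therefore stands lowest of the three numbers, with compound 2 nearest and compound 1 furthest above it.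

Compound 4, `N#CC1=C(/N=C/c2ccc([N+](=O)[O-])cc2[N+](=O)[O-])N(c2ccc(S(N)(=O)=O)cc2)C2=C(C(=O)CCC2)C1c1ccc(Cl)cc1Cl`, has not yet been measured in this assay. It differs from compound 3 by 2,4-dinitrophenyl in place of 2-(4-(dimethylamino)phenyl)ethenyl on a carbon with a double bond to nitrogen. Among the compounds with values here, the step that bears most directly on this change is the one from compound 2 to compound 3, which sits on the same carbon with a double bond to nitrogen and was modest and downward; the earlier step from compound 1 to compound 2, also modest and downward, touched the same region. Neither step, however, introduced a 2,4-dinitrophenyl group, so the direction of this new step is uncertain. Because the shorter group in compound 2 gave 40% while the longer group in compound 3 gave 20%, compound 4 is expected to fall between those two levels. Compound 4 is thus estimated at 30%, within 10% to 55%, an expected step of a number 10 percentage points higher from compound 3 to compound 4 (within the scatter).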

Compound 4, a percentage reported as activity, at one concentration (the size of the read-out at that concentration, not a potency): 20%
Beside the measured number, compound 4's estimate is 10 percentage points above it; measured number inside the range.
By their numbers in this assay, from the lowest: compounds 3 and 4 (each within the scatter of the next); then compound 2; then compound 1.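

In this assay, within the data shown here, putting 2,4-dinitrophenyl in place of 2-(4-(dimethylamino)phenyl)ethenyl on a carbon with a double bond to nitrogen gives no change at the digits printed from compound 3 to compound 4 (within the scatter), so at this place two groups that share only one six-membered aromatic ring of carbon only read alike. The exchange of 4-(dimethylamino)phenyl for 2,4-dinitrophenyl gives a number 20 percentage points lower from compound 2 to compound 4 (beyond the scatter), which shows that the lower level seen with compound 3 does not require an ethenyl link, as compound 4 has none and still reads alike. No measurement at hand bears on what lies behind these readings.

Going by these compounds, whether an unsubstituted phenyl, a 4-nitrophenyl or a 4-hydroxyphenyl group on this carbon would read like compound 2 or like compound 4 stays open. Also open is whether an amide with a longer chain at this place would read like compound 1, and how all of these compounds would compare at other concentrations or exposure times.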